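Bromo on the limit-bound compound 3

A few compounds are considered here, and "the series" means these few. Any claim that something is new, unique, unknown or untested is made for them only; others in the source may bear on it.

Compound 1 `CN(CCCn1c(=O)sc2ccc(Br)cc21)Cc1ccccc1` gives 26500 nM
Compound 2 `CN(CCCn1c(=O)sc2cc(Br)ccc21)Cc1ccccc1` gives 13200 nM
Compound 3 `O=c1oc2ccccc2n1CCCN1Cc2ccccc2C1` gives > 100000 nM (a limit, not a number)

Within the data shown here, all three values come from an ADME assay on SH-SY5Y cells (Homo sapiens) for cytotoxicity, read by MTT assay, with a stated time of 72 h (a higher number here means a weaker inhibitor, a lower number a stronger inhibitor), and are the only readings available for this series. Among the measured compounds shown here, compound 3 has no numerical value in this assay and stands at the limit of > 100000 nM in this assay, at which 1 of the 3 values shown sits, as its only reading. Any step that starts from compound 3 therefore starts from a limit and not from a number.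

The next compound is compound 4 `O=c1oc2cc(Br)ccc2n1CCCN1Cc2ccccc2C1` which has bromo in place of hydrogen on an aromatic carbon and has not yet been measured. For the measured compounds named here, no measured pair isolates this change, so the expectation has only indirect support. Compound 1 (26500 nM) carries bromo and returns a number. Compound 2 (13200 nM) also carries bromo and returns a number. On that basis a move toward a lower number is expected, and the expected change is an at least 2.2-fold lower number from compound 3 to compound 4 (0.34 log units; beyond the scatter) in this assay with a real chance that the reading remains a limit.

Compound 4 is estimated at 45000 nM with 15000 nM to 100000 nM as the expected range.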

Compound 4, half-maximal inhibitory concentration: > 100000 nM
Compound 4 was reported as a limit (the forecaster's own chance of this, stated with the estimate: 35%); middle value at least 2.2-fold (0.34 log units) away from the limit.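

In this assay compound 3 and compound 4 both return a limit and not a number, so the change from hydrogen to bromo cannot be read as a step between them: the limit of > 100000 nM in this assay, at which 2 of the 4 values shown sit.

The compounds shown leave open whether bromo in place of hydrogen on an aromatic carbon changes the reading at all on the core of compound 3.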